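Methyl in Place of Fluoro on Compound 2

The source may hold more compounds than are shown below. What is called first, only, known or untested is meant among the compounds shown, and "the series" means these compounds.

Among the compounds with values here, compound 2 `Oc1ccc2[nH]c(CN3CCC(Cc4ccc(F)cc4)CC3)nc2c1` stands at the lower of the two numbers measured so far: in an assay on membranes from brain for binding affinity to Adrenergic receptor alpha-1 (Rattus norvegicus) (on this read-out lower numbers stand for stronger inhibition and higher numbers for weaker inhibition), compound 2 gives 620 nM. Within the data shown here, the only other measured compound, compound 1 `Oc1cccc2[nH]c(Cc3ccc(Oc4ccccc4)cc3)nc12`, gives 5500 nM in this assay, and the gap between the two lies beyond the usual scatter. The next compound, compound 3 `Cc1ccc(CC2CCN(Cc3nc4cc(O)ccc4[nH]3)CC2)cc1`, is compound 2 changed in a single place: methyl in place of fluoro on an aromatic carbon. Among the measured compounds shown here, no measured pair shows this change, so its effect is not known from the numbers at hand. The swap exchanges one heavy atom for another of the same size on the same aromatic carbon, so compound 3 is expected to stay close to compound 2, with a step from compound 2 to compound 3 of a 1.2-fold higher number from compound 2 to compound 3 (0.08 log units; within the scatter) that likely falls within the scatter. Compound 3 is therefore estimated at 750 nM, with a plausible range from 250 nM to 2200 nM.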

Compound 3, half-maximal inhibitory concentration: 830 nM
Beside the measured number, compound 3's estimate is 1.1-fold (0.04 log units) below it; the range from low to high includes it.
By their numbers in this assay, from the lowest: compounds 2 and 3 (each within the scatter of the next); then compound 1.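

In this assay, the change from 4-fluorophenyl to 4-methylphenyl gives a 1.3-fold higher number from compound 2 to compound 3 (0.13 log units; within the scatter), so this single replacement on an aromatic carbon, para to a large group, does not separate the two compounds. Within the data shown here, the earlier compounds offered no pair differing in one place, which makes this the first reading of a single change, and it shows that fluoro and methyl at this position cannot be told apart on this read-out. Nothing at hand explains why the two groups read alike.

Still open, on these data alone, is how this position responds to groups unlike these two, such as an amine, a carboxylic acid or a longer chain like propyl on the same aromatic carbon. Also open, as far as these compounds go, is how a plain phenyl, with only hydrogen at this position, would compare with compound 2 and compound 3.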